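Aryl amide variation in a glioma cell toxicity series

A few compounds are considered here, and "the series" means these few. Any claim that something is new, unique, unknown or untested is made for them only; others in the source may bear on it.

Compound 1, `Nc1ccccc1NC(=O)CCCNCC(=O)Nc1ccc(Br)cc1`, in a functional assay on U-251 cells (Homo sapiens) for inhibition, read by MTT assay, with a stated time of 2 days (on this read-out lower numbers stand for higher toxicity in this test and higher numbers for lower toxicity in this test), gives > 100000 nM, a limit of the assay and not a number.
Compound 2, `Nc1ccccc1NC(=O)CCCNCC(=O)Nc1cc(Cl)ccc1Cl`, in this assay gives > 100000 nM, again a limit of the assay.

For the measured compounds named here, compound 2 therefore stands at the limit, and the one other value in this assay stands at the same place: the limit of > 100000 nM in this assay, at which 2 of the 2 values shown sit. Going by the values given here, the single measured step, a step that the two limits leave unreadable from compound 1 to compound 2, is one that the two limits leave unreadable, so its size is not known.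

Compound 3, `COc1ccc(NC(=O)CNCCCC(=O)Nc2ccccc2N)cc1`, differs from compound 2 in one place: 4-methoxyphenyl in place of 2,5-dichlorophenyl on an amide-type nitrogen. The measured step that bears on it concerns the same amide-type nitrogen, but gives no readable size, so no direction and no size beyond the scatter can be taken from it for this assay.

Given (the limit of > 100000 nM in this assay, at which 2 of the 2 values shown sit), compound 3 is expected to remain at the limit in this assay as well. The estimate for compound 3 is 150000 nM, with a range from 60000 nM to 400000 nM. This estimate means a step that the limit leaves unreadable from compound 2 to compound 3, which is expected to be no more than the scatter.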

Compound 3, concentration lethal to 50% of the cells: > 100000 nM
Compound 3: no number, only a limit; the forecaster's own chance of this, stated with the estimate: 80%; the middle value is on the limit's open side.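

In this assay compound 3 gives > 100000 nM as a limit of the assay and not a number. For the compounds shown here, no step among compound 1, compound 2 and compound 3 can be read, as all three sit at one place: the limit of > 100000 nM in this assay, at which 3 of the 3 values shown sit.
The compounds shown leave open whether the 4-bromophenyl, 2,5-dichlorophenyl and 4-methoxyphenyl groups differ at all in toxicity to these cells.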